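A few compounds are considered here, and "the series" means these few. Any claim that something is new, unique, unknown or untested is made for them only; others in the source may bear on it.

Measured so far:
compound 1, `CN(C)C(=O)c1cc2cnc(Nc3ccc(NC(=O)C4(C(=O)Nc5cccc(O)c5)CC4)cc3)nc2n1C1CCCC1`, 80.7%
compound 2, `CN(C)C(=O)c1cc2cnc(Nc3ccc(NC(=O)C4(C(=O)Nc5ccc(Br)cc5)CC4)cc3)nc2n1C1CCCC1`, 21.1%
compound 3, `CN(C)C(=O)c1cc2cnc(Nc3ccc(NC(=O)C4(C(=O)Nc5ccc(Cl)c(C(F)(F)F)c5)CC4)cc3)nc2n1C1CCCC1`, 6.9%

In a functional assay on T47D cells (Homo sapiens) for inhibition, read by CCK-8 assay, with a stated time of 72 h, tested at 1 uM (a lower number here means less inhibition of growth, a higher number more inhibition of growth at the concentration tested), compound 2 stands second highest of the three numbers, well below compound 1 and above compound 3. Both steps involving compound 2 are beyond the scatter: a number 59.6 percentage points lower from compound 1 to compound 2 (beyond the scatter) is large, while a number 14.2 percentage points lower from compound 2 to compound 3 (beyond the scatter) is modest.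

Compound 4, `COc1cccc(NC(=O)C2(C(=O)Nc3ccc(Nc4ncc5cc(C(=O)N(C)C)n(C6CCCC6)c5n4)cc3)CC2)c1`, has not yet been measured. Its difference from compound 2 is 3-methoxyphenyl in place of 4-bromophenyl on an amide-type nitrogen.

The bearing steps are those on the same amide-type nitrogen. The large fall a number 59.6 percentage points lower from compound 1 to compound 2 (beyond the scatter) shows that exchanging 3-hydroxyphenyl for 4-bromophenyl costs most of the growth inhibition, and a number 73.8 percentage points lower from compound 1 to compound 3 (beyond the scatter) repeats the pattern with a second halogenated ring. The entering 3-methoxyphenyl resembles the 3-hydroxyphenyl of compound 1 more closely than the leaving 4-bromophenyl does, though it carries an acceptor rather than a donor, so the step from compound 2 to compound 4 in this assay is expected to run upward, beyond the scatter, but probably not all the way back to the level of compound 1, as a number 30.9 percentage points higher from compound 2 to compound 4 (beyond the scatter). For compound 4 the expected value in this assay is therefore 52%, with a range from 25% to 78%.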

Compound 4, percent growth inhibition at one concentration: 56.3%
Compound 4: middle estimate off by 4.3 percentage points, on the low side; measured number inside the range.
By their numbers in this assay, from the lowest: compound 3; then compound 2; then compound 4; then compound 1.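

In this assay, the halogenated rings on the amide-type nitrogen do not set the ceiling for this position: the gain of a number 35.2 percentage points higher from compound 2 to compound 4 (beyond the scatter) and the gain of a number 49.4 percentage points higher from compound 3 to compound 4 (beyond the scatter) show that 3-methoxyphenyl restores much of the growth inhibition, and both gains lie beyond the scatter. Within the data shown here, the methyl on the oxygen still comes at a price, with a number 24.4 percentage points lower from compound 1 to compound 4 (beyond the scatter) beyond the scatter as well, so 3-methoxyphenyl and 3-hydroxyphenyl are not interchangeable here, and across these four compounds the two oxygen-bearing rings stand above the two halogenated ones, with no compound going against that order. Nothing at hand gives a measured basis for any of these differences.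

The 3-methoxyphenyl and 4-bromophenyl rings differ in both the substituent and its place on the ring, so these compounds do not separate the two; 3-bromophenyl and 4-methoxyphenyl would do so. On these data alone, it also remains open whether the higher level of compound 1 is specific to the hydroxyl or would extend to another group at that place, such as an amine in 3-aminophenyl.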